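From 3-methoxythiophen-2-yl to 4-methoxythiophen-2-yl

The compounds below may be only part of what the source reports. "The series", "measured", "known", "first", "only" and "open" are said of these compounds alone.

Two compounds have entries so far, compound 1 `COc1cc(/C=C\c2cc3cc(O)ccc3s2)cc(OC)c1OC` and compound 2 `COc1ccsc1/C=C\c1cc(OC)c(OC)c(OC)c1`. In a functional assay on MIA PaCa-2 cells (Homo sapiens) for antiproliferative activity, read by MTT assay, with a stated time of 72 h (on this read-out higher numbers stand for weaker inhibition and lower numbers for stronger inhibition), compound 1 is recorded as "not determined" (no result reported), so it offers no number for comparison.

In this assay compound 2 gives > 1000 nM, which is a limit of the assay and not a number.

Compound 3 `COc1csc(/C=C\c2cc(OC)c(OC)c(OC)c2)c1` contains the same atoms as compound 2, joined differently. The change 4-methoxythiophen-2-yl in place of 3-methoxythiophen-2-yl on a double-bonded chain carbon bound to a double-bonded chain carbon puts 4-methoxythiophen-2-yl in place of 3-methoxythiophen-2-yl on a double-bonded chain carbon bound to a double-bonded chain carbon.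

Among the measured compounds shown here, no measured step gives the size of such a change, and no direction can be read from the data. The working expectation in this assay is therefore no shift beyond the scatter, with weak inhibition retained. The estimated step that the limit leaves unreadable from compound 2 to compound 3 is expected to remain small. For compound 3 the estimated half-maximal inhibitory concentration is 1500 nM, with an expected range of 250 nM to 10000 nM.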

Compound 3, half-maximal inhibitory concentration: 14 nM
Estimate against measurement, compound 3: 110-fold (2.03 log units) above; measured number below the stated range.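

In this assay, the series gains its first readable change: 4-methoxythiophen-2-yl in place of 3-methoxythiophen-2-yl, on a double-bonded chain carbon bound to a double-bonded chain carbon, gives an at least 71-fold lower number from compound 2 to compound 3 (1.85 log units; beyond the scatter). The two groups match in heavy atoms, hydrogen-bond donors and acceptors, so within this pair a change in how the same atoms are joined is enough to separate a compound with a limit from one with a single number. The value of compound 2, > 1000 nM, is a limit of the assay and not a number, so the step is a bound and not a measured size: the limit of > 1000 nM in this assay, at which 1 of the 3 values shown sits.

Compound 1 stands as "not determined" (no result reported) in this assay, so this single pair is all that bears on the change, and it gives no cause for the step. Open questions are whether the low number of compound 3 survives when an amine or a carboxylic acid replaces the methoxy group of 4-methoxythiophen-2-yl, and whether the step recurs when another part of the shared core changes.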